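Ethoxy to isopropoxy on the shared core

The source may report more compounds than this note shows. Statements on the series, on what has been measured and on what is new or still open speak of the compounds shown alone.

Compound 1, `CCOc1nn2cc(-c3cc4ccccc4o3)nc2s1`, is the reference point of this small set. In an assay for antagonist activity at proteinase-activated receptor 4 (Homo sapiens), with stated times of 5 min, 50 s and 15 min, in the presence of a further agent that is not named here (a higher number here means a weaker inhibitor, a lower number a stronger inhibitor), compound 1 gives 2100 nM, the higher of the two numbers recorded. Compound 2, `COc1cc(OC)c2cc(-c3cn4nc(OC)sc4n3)oc2c1`, gives 74 nM in this assay, a lower number by a margin beyond the usual scatter, so compound 1 is the weaker of the two. Compound 3, `COc1ccc2oc(-c3cn4nc(OC)sc4n3)cc2c1`, returns only a limit in this assay, > 30000 nM, which is the limit of > 30000 nM in this assay, at which 1 of the 3 values shown sits, and not a number. Within the data shown here, no two of the measured compounds differ in a single place, so no measured step is available.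

Compound 4, `CC(C)Oc1nn2cc(-c3cc4ccccc4o3)nc2s1`, is the next point. It differs from compound 1 by methyl in place of hydrogen on a saturated chain carbon bound to an oxygen on an aromatic ring and a saturated chain carbon. The change is the smallest possible extension of the ethoxy chain, and the set holds no comparison that would anchor it. The expected step is a 1.2-fold higher number from compound 1 to compound 4 (0.08 log units; within the scatter), within the usual scatter and with no direction favoured. Compound 4 is therefore estimated at 2500 nM in this assay, with a range from 800 nM to 8000 nM.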

Compound 4, half-maximal inhibitory concentration: > 30000 nM
Compound 4: a limit, no number; the forecaster's own chance of this, stated with the estimate: 10%; at least 12-fold (1.07 log units) between middle value and limit.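

Among these compounds, the first measured step at this position is an at least 14-fold higher number from compound 1 to compound 4 (1.15 log units; beyond the scatter) in this assay, and it lies beyond the scatter. On these data alone, the value of compound 4 is a limit of the assay and not a number, so the full size of the step stays unknown. A single methyl on the saturated chain carbon bound to an oxygen on an aromatic ring is thus enough to turn the measurable number of compound 1 into a limit, and such values now form a larger part of the set: the limit of > 30000 nM in this assay, at which 2 of the 4 values shown sit.

The compounds shown do not tell whether this loss follows from branching at that carbon or from chain size alone, and a straight propoxy chain on the shared core would separate the two. As far as these compounds go, how an amine in place of the ethoxy group would read in this assay also remains open.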